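This account rests on a few compounds, and the source may have more. Where it says the series, first, only, none or still open, it means among the compounds named here.

Working notes on the series. Two compounds have numbers in a functional assay on HepG2 cells (Homo sapiens) for antiproliferative activity, read by MTT assay, with a stated time of 48 h (a lower number here means a stronger inhibitor, a higher number a weaker inhibitor), so far. Compound 1 `COc1ccc(-c2ccc3c(c2)C(=O)C(=O)N3C)cc1` gives 6670 nM in this assay. Compound 2 `COC(=O)/C=C1\C(=O)N(Cc2ccc(OC)cc2)c2ccc(-c3ccc(OC)cc3)cc21` gives 4730 nM in this assay, the lowest of the two values, with compound 1 the nearest and within the scatter of it, so no order between the two can be claimed.

Compound 3 `COc1ccc(CN2C(=O)/C(=C\c3ccc(C(F)(F)F)cc3)c3cc(-c4ccc(OC)cc4)ccc32)cc1` has not yet been measured in this assay. It differs from compound 2 in one place: 4-(trifluoromethyl)phenyl in place of methoxycarbonyl on a double-bonded chain carbon bound to a double-bonded ring carbon. Going by the values given here, no step between measured compounds is available, and the two values in hand say nothing about this kind of exchange; the replacement is a large one, so any expectation is loosely founded. The step from compound 2 to compound 3 is estimated at a 2.2-fold lower number from compound 2 to compound 3 (0.33 log units; beyond the scatter), a modest move toward a lower number, close to the edge of the scatter. For compound 3 the expected value in this assay is 2200 nM, within 500 nM to 9000 nM.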

Compound 3, half-maximal inhibitory concentration: > 10000 nM
Compound 3 ended at the assay's limit; the forecaster's own chance of this, stated with the estimate: 5%; middle value at least 4.5-fold (0.65 log units) away from the limit.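

In this assay, replacing methoxycarbonyl with 4-(trifluoromethyl)phenyl on a double-bonded chain carbon bound to a double-bonded ring carbon gives an at least 2.1-fold higher number from compound 2 to compound 3 (0.32 log units; beyond the scatter). Going by these compounds alone, this is the first step read at this position, and it shows that the position is not indifferent to the exchange, with the larger aromatic group going with the weaker result. The reading for compound 3 is a limit of the assay and not a number, so the step has a lower bound only: the limit of > 10000 nM in this assay, at which 1 of the 3 values shown sits.

Within the data shown here, the single exchange does not separate the aromatic ring from its trifluoromethyl group, so it remains open which part goes with the step. From the compounds shown here alone, how an unsubstituted phenyl or a carboxylic acid would read at this position also remains open.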